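The source may hold more compounds than are shown below. What is called first, only, known or untested is meant among the compounds shown, and "the series" means these compounds.

Measured so far:
compound 1, `CCCCN1CCC(C(=O)Nc2cc(Cl)c(N)cc2OC)CC1` — > 10 mg/kg
compound 2, `COc1cc(N)c(Cl)cc1NC(=O)C1CCN(Cc2ccc(OCc3ccccc3)cc2)CC1` — > 4 mg/kg

The two measured compounds share a core and differ only in the group attached to the ring nitrogen. In a functional assay on the whole organism for antagonist activity, with Mus musculus as the target (on this read-out lower numbers stand for an effect already at smaller amounts and higher numbers for an effect only at larger amounts of compound), compound 1 gives > 10 mg/kg, which is a limit of the assay and not a number, as the limit of > 10 mg/kg in this assay, at which 1 of the 2 values shown sits, shows. In this assay compound 2 gives > 4 mg/kg, likewise a limit and not a number, as the limit of > 4 mg/kg in this assay, at which 1 of the 2 values shown sits, shows. Compound 1 therefore stands at a limit, and the other value shown is a limit as well, so no order between the two compounds follows from the numbers.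

Compound 3, `COc1cc(N)c(Cl)cc1NC(=O)C1CCN(Cc2ccsc2)CC1`, has not yet been measured in this assay. It differs from compound 1 by thiophen-3-yl in place of propyl on a saturated chain carbon bound to an amine nitrogen in a ring. Going by the values given here, no step between measured compounds is known, so nothing in the data sets the size of this step. A step of moderate size toward an effect at smaller amounts is expected, an at least 3.3-fold lower number from compound 1 to compound 3 (0.52 log units; beyond the scatter), though with wide uncertainty, and a result reported only as a limit remains quite possible. For compound 3 the dose for half-maximal effect in this assay is estimated at 3 mg/kg, within a range of 0.5 mg/kg to 20 mg/kg.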

Compound 3, dose for half-maximal effect: 3.4 mg/kg
Compound 3: middle estimate off by 1.1-fold (0.05 log units), on the low side, and the stated range covers the measured number.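

Compound 3 is the first compound shown that gives a true number and not a limit in this assay, so an effect in the whole animal can be reached within this series when the group on a saturated chain carbon bound to an amine nitrogen in a ring is changed. Putting thiophen-3-yl in place of propyl, with the rest of the molecule untouched, gives an at least 2.9-fold lower number from compound 1 to compound 3 (0.46 log units; beyond the scatter), a change in a single place that is large enough to stand clear of ordinary variation between repeated measurements. This size is only a minimum, and the real step could be larger, because compound 1 stands at a limit: the limit of > 10 mg/kg in this assay, at which 1 of the 3 values shown sits.

A single step cannot show whether the gain comes from having an aromatic ring at this place, from the sulfur atom, or simply from the larger group, and the data give no cause for it. A phenyl group or a thiophen-2-yl group at the same place would begin to separate these possibilities, while a pentyl chain would test whether size alone is enough.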